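This account rests on a few compounds, and the source may have more. Where it says the series, first, only, none or still open, it means among the compounds named here.

The measured compounds:

compound 1, `O=C(Nc1ccc(Oc2ccnc3[nH]ccc23)cc1)c1cc2cccnc2n(-c2ccc(Cl)cc2)c1=O`, which in a functional assay on A549 cells (Homo sapiens) for antiproliferative activity, read by MTT assay, with a stated time of 72 h (a lower number here means a stronger inhibitor, a higher number a weaker inhibitor), gives 290 nM;
compound 2, `COc1ccc(-n2c(=O)c(C(=O)Nc3ccc(Oc4ccnc5[nH]ccc45)cc3)cc3cccnc32)cc1`, which in this assay gives 930 nM;
compound 3, `Cn1ccc2c(Oc3ccc(NC(=O)c4cc5cccnc5n(-c5ccc(Cl)cc5)c4=O)cc3)ccnc21`, which in this assay gives 630 nM.

Compound 3 stands second highest of the three numbers in this assay. Its nearest neighbour is compound 2, whose number sits within the scatter of that of compound 3, so the two cannot be told apart. Compound 1 lies further off, and the step of a 2.2-fold higher number from compound 1 to compound 3 (0.34 log units; beyond the scatter) is beyond the scatter.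

Compound 4, `COc1ccc(-n2c(=O)c(C(=O)Nc3ccc(Oc4ccnc5c4ccn5C)cc3)cc3cccnc32)cc1`, has not yet been measured. It differs from compound 3 in one place: methoxy in place of chloro on an aromatic carbon. The same change has been measured once before, between compound 1 and compound 2, where a 3.2-fold higher number from compound 1 to compound 2 (0.51 log units; beyond the scatter) was recorded, a modest loss that lies beyond the scatter. Going by the values given here, that is the only measured instance, and the methyl on the aromatic nitrogen shared by compound 3 and compound 4 has likewise been measured only once, as a 2.2-fold higher number from compound 1 to compound 3 (0.34 log units; beyond the scatter); whether the two changes interact is not known. On this evidence a step of similar size and direction is expected for compound 4, namely a 3.2-fold higher number from compound 3 to compound 4 (0.50 log units; beyond the scatter). Compound 4 is therefore estimated at 2000 nM, with a range from 900 nM to 4500 nM.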

Compound 4, half-maximal inhibitory concentration: 3460 nM
Beside the measured number, compound 4's estimate is 1.7-fold (0.24 log units) below it, and the stated range covers the measured number.
By their numbers in this assay, from the lowest: compound 1; then compounds 3 and 2 (each within the scatter of the next); then compound 4.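

In this assay, the change from 4-chlorophenyl to 4-methoxyphenyl now raises the number on a second core, with a 5.5-fold higher number from compound 3 to compound 4 (0.74 log units; beyond the scatter), so the loss no longer rests on a single pair and keeps its direction, with a size that cannot be told apart from the first instance: the same change on two cores in this assay, a 3.2-fold higher number (0.51 log units; beyond the scatter) from compound 1 to compound 2 and a 5.5-fold higher number (0.74 log units; beyond the scatter) from compound 3 to compound 4, 1.7-fold (0.23 log units) apart, within the scatter of two such steps. Methyl in place of hydrogen on the aromatic nitrogen also repeats in direction, now in the presence of the methoxy group, with a 3.7-fold higher number from compound 2 to compound 4 (0.57 log units; beyond the scatter), and again the two instances cannot be told apart in size: the same change on two cores in this assay, a 2.2-fold higher number (0.34 log units; beyond the scatter) from compound 1 to compound 3 and a 3.7-fold higher number (0.57 log units; beyond the scatter) from compound 2 to compound 4, 1.7-fold (0.23 log units) apart, within the scatter of two such steps. Together these four compounds answer the question of interaction as far as they can, since each change has much the same size whichever form the other part takes, and any interaction between the two stays within the scatter.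

The compounds shown leave open whether the higher number is particular to methoxy or would also follow from a fluoro, a methyl, an amine or a carboxylic acid at this position. They also leave open what a longer chain, such as ethyl or propyl, would do on the aromatic nitrogen, and they say nothing about why either change raises the number.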